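Ester in Place of Sulfonamide on the Biaryl Core

The source may hold more compounds than are shown below. What is called first, only, known or untested is meant among the compounds shown, and "the series" means these compounds.

This account concerns three measured compounds and one that awaits measurement. In an assay on COS-7 cells for inhibition of patatin-like phospholipase domain-containing protein 2 (Mus musculus) (on this read-out higher numbers stand for weaker inhibition and lower numbers for stronger inhibition), compound 1 `CCOC(=O)c1cccc(-c2ccsc2)c1` gives 75000 nM. Compound 2 `CCOC(=O)c1cccc(-c2ccc(OCC)c([N+](=O)[O-])c2)c1` gives 200000 nM in this assay, and compound 3 `CCOc1ccc(-c2cccc(S(=O)(=O)NC)c2)cc1` gives 200000 nM. Compound 3 stands level with compound 2 at the digits shown, and the two together hold the highest numbers of the three; its nearest neighbour is compound 2, with no change within the scatter, while compound 1, the furthest, lies a lower number away, beyond the scatter.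

Compound 4 `CCOc1ccc(-c2cccc(C(=O)OCCOC)c2)cc1` differs from compound 3 in one place: (2-methoxyethoxy)carbonyl in place of methylsulfamoyl on an aromatic carbon. Among the measured compounds shown here, no step between measured compounds matches this change, so its size cannot be read off directly. Compound 1 carries an ester and shows 75000 nM, and compound 2, which also carries an ester, shows 200000 nM. Resting on those two values, compound 4 is expected at 100000 nM with a range of 40000 nM to 250000 nM. The expected step from compound 3 to compound 4 is therefore a 2.0-fold lower number from compound 3 to compound 4 (0.30 log units; within the scatter), a modest move toward stronger inhibition that may not exceed the scatter.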

Compound 4, half-maximal inhibitory concentration: 70000 nM
The estimate for compound 4 lay 1.4-fold (0.15 log units) above the measured number; the measured number falls inside the stated range.
By their numbers in this assay, from the lowest: compounds 4 and 1 (each within the scatter of the next); then compounds 2 and 3 (each within the scatter of the next).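

Among the compounds shown here, at this position, an aromatic carbon of a six-membered aromatic ring of carbon only, the earlier compounds offered no single-place change to read. In this assay the exchange of methylsulfamoyl for (2-methoxyethoxy)carbonyl now gives a 2.9-fold lower number from compound 3 to compound 4 (0.46 log units; beyond the scatter) and so shows that the number responds to the group held here, with the one hydrogen-bond donor of the leaving group absent from the entering group and the chain longer by the count of heavy atoms. Which of these differences matters cannot be told from this one step, and no measurement at hand explains it.

As far as these compounds go, how a carboxylic acid or a primary amide would read at this position remains open. So does whether the step belongs to the carbonyl or to the 2-methoxyethoxy chain, which a plain methyl ester or a longer ether chain could help to separate.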